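Moving from butylsulfonyl to a sulfonyl-hydrazide on the amide

The compounds below may be only part of what the source reports. "The series", "measured", "known", "first", "only" and "open" are said of these compounds alone.

Measured so far:
compound 1, `CC[C@H](C)[C@H](NC(=O)c1cccc(Cn2ccnc2)c1)C(=O)Nc1nccs1`, 42000 nM
compound 2, `CCCCS(=O)(=O)NC(=O)[C@@H](NC(=O)c1cccc(Cn2ccnc2)c1)[C@@H](C)CC`, 9900 nM

In an assay on HEK293 cells for displacement of a labelled ligand from Type-2 angiotensin II receptor (Homo sapiens) (a higher number here means a weaker inhibitor, a lower number a stronger inhibitor), compound 2 gives the lowest of the two numbers; the only other, compound 1, lies higher by a 4.2-fold lower number from compound 1 to compound 2 (0.63 log units; beyond the scatter). Compound 3, `CC[C@H](C)[C@H](NC(=O)c1cccc(Cn2ccnc2)c1)C(=O)NNS(=O)(=O)c1ccc(C)cc1`, differs from compound 2 by ((4-methylphenyl)sulfonyl)amino in place of butylsulfonyl on an amide-type nitrogen. Among the compounds with values here, the one measured step concerns a different exchange at the same nitrogen, so no step speaks directly to this change. Compound 3 is therefore expected to change by about a 1.2-fold lower number from compound 2 to compound 3 (0.09 log units; within the scatter), that is, nothing beyond the scatter. The estimate for compound 3 is 8000 nM, ranging from 2000 nM to 32000 nM.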

Compound 3, inhibition constant: 29000 nM
Estimate against measurement, compound 3: 3.6-fold (0.56 log units) below; low and high end bracket the measured number.
By their numbers in this assay, from the lowest: compound 2; then compounds 3 and 1 (each within the scatter of the next).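

In this assay, putting ((4-methylphenyl)sulfonyl)amino on the amide-type nitrogen gives a 2.9-fold higher number from compound 2 to compound 3 (0.47 log units; beyond the scatter) and so does not keep the gain seen with butylsulfonyl. The comparison with 1,3-thiazol-2-yl gives a 1.4-fold lower number from compound 1 to compound 3 (0.16 log units; within the scatter), which leaves the two groups level, so a sulfonyl group at this nitrogen does not by itself keep the number low. Nothing on hand explains the difference between these groups.

Going by these compounds, this exchange adds both a nitrogen and an aromatic ring, so their separate contributions remain open. Phenylsulfonyl directly on the amide nitrogen, or butylsulfonylamino, would separate them.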